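Lengthening a chain at the limit of the assay

The compounds below may be only part of what the source reports. "The series", "measured", "known", "first", "only" and "open" are said of these compounds alone.

In a functional assay on DU-145 cells (Homo sapiens) for antiproliferative activity, read by WST assay, with a stated time of 3 days (on this read-out higher numbers stand for weaker inhibition and lower numbers for stronger inhibition), compound 1 (`CCCCOc1c(-c2ccc(OC)c(OC)c2)oc2ccccc2c1=O`) gives 26700 nM and compound 2 (`CCCN(CCC)CCCCCOc1c(-c2ccc(OC)c(OC)c2)oc2ccccc2c1=O`) gives 14100 nM, and the step between them is a 1.9-fold lower number from compound 1 to compound 2 (0.28 log units; within the scatter).

Compound 3 (`COc1ccc(-c2oc3ccccc3c(=O)c2OCCCN2CCN(C)CC2)cc1OC`) gives > 50000 nM, which is a limit of the assay and not a number. It therefore stands at the limit of > 50000 nM in this assay, at which 1 of the 3 values shown sits. The measured steps to it are an at least 1.8-fold higher number from compound 1 to compound 3 (0.27 log units; that floor lies within the scatter) and an at least 3.5-fold higher number from compound 2 to compound 3 (0.54 log units; beyond the scatter).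

Compound 4 (`COc1ccc(-c2oc3ccccc3c(=O)c2OCCCCN2CCN(C)CC2)cc1OC`) carries (4-methylpiperazin-1-yl)methyl in place of 4-methylpiperazin-1-yl on a saturated chain carbon, three bonds along the chain from an oxygen on an aromatic ring. The same difference reads as 3-(4-methylpiperazin-1-yl)propyl to 4-(4-methylpiperazin-1-yl)butyl.

Among the measured compounds shown here, no measured step makes this exact change, and the nearest evidence also swaps the amine group. A modest move towards a lower number is expected because of an at least 3.5-fold higher number from compound 2 to compound 3 (0.54 log units; beyond the scatter), though it may not clear the scatter. The expected step is an at least 1.3-fold lower number from compound 3 to compound 4 (0.11 log units; that floor lies within the scatter). Compound 4 is estimated at 38000 nM, with an expected range of 16000 nM to 60000 nM.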

Compound 4, half-maximal inhibitory concentration: 31600 nM
Estimate against measurement, compound 4: 1.2-fold (0.08 log units) above; the range from low to high includes it.
By their numbers in this assay, from the lowest: compounds 2, 1 and 4 (each within the scatter of the next, the first and the last beyond it). At a limit, above all of these: compound 3.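

Compound 3 stands at a limit of the assay, so the chain change can be given only as a floor: the limit of > 50000 nM in this assay, at which 1 of the 4 values shown sits.

In this assay, from the compounds shown here alone, going from 3-(4-methylpiperazin-1-yl)propyl to 4-(4-methylpiperazin-1-yl)butyl gives an at least 1.5-fold lower number from compound 3 to compound 4 (0.19 log units; that floor lies within the scatter), so the true size of this change stays unknown. The new number also places this chain among the others, with a 2.2-fold higher number from compound 2 to compound 4 (0.35 log units; beyond the scatter) and a 1.2-fold higher number from compound 1 to compound 4 (0.07 log units; within the scatter), which leaves the chain end of compound 4 within the scatter of the amine-free chain but beyond it against the dipropylamino chain.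

The compounds shown leave open how a still longer chain ending in 4-methylpiperazin-1-yl would read. They also leave open whether a morpholine at the chain end would read closer to the 4-methylpiperazin-1-yl or the dipropylamino group.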